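Methyl Next to the Ring Nitrogen in Compound 3

The source may hold more compounds than are shown below. What is called first, only, known or untested is meant among the compounds shown, and "the series" means these compounds.

Measured compounds:
compound 1, `N/C(=N\NC(=S)N1CCCCCC1)c1ccccn1`: 88.7%
compound 2, `Cc1ccnc(/C(N)=N/NC(=S)N2CCCCCC2)c1`: 91.6%

In a functional assay on HeLa cells (Homo sapiens) for cytotoxicity, read by MTT assay, with a stated time of 72 h, tested at 100 uM (on this read-out higher numbers stand for more inhibition of growth at the one concentration tested and lower numbers for less inhibition of growth), compound 1 gives 88.7% and stands lowest of the two numbers, with compound 2 as its nearest neighbour; the gap a number 2.9 percentage points higher from compound 1 to compound 2 (within the scatter) lies within the scatter, so the two numbers are not told apart.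

Compound 3, `Cc1cccc(/C(N)=N/NC(=S)N2CCCCCC2)n1`, is not yet measured. It differs from compound 1 by methyl in place of hydrogen on an aromatic carbon, the methyl sitting on an aromatic carbon of a six-membered aromatic ring with one nitrogen, next to the ring nitrogen and meta to a large group. For the measured compounds named here, the only measured step that bears on this change is the one in which a methyl was placed elsewhere on the same ring: a number 2.9 percentage points higher from compound 1 to compound 2 (within the scatter), within the scatter. On that single step no change beyond the scatter is expected for compound 3 in this assay, and the expected step of a number 0.3 percentage points higher from compound 1 to compound 3 (within the scatter) is small. Compound 3 is therefore estimated at 89%, with a range from 78% to 97%.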

Compound 3, percent growth inhibition at one concentration: 82.7%
Beside the measured number, compound 3's estimate is 6.3 percentage points above it, within the range that was stated.
By their numbers in this assay, from the lowest: compounds 3, 1 and 2 (each within the scatter of the next).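

In this assay, methyl in place of hydrogen on an aromatic carbon, here next to the ring nitrogen and meta to a large group, gives a number 6 percentage points lower from compound 1 to compound 3 (within the scatter), so this position also shows no change that can be told from the scatter. The earlier compounds had shown this only for a methyl placed elsewhere on the same ring; compound 3 extends it to the position next to the ring nitrogen, where growth inhibition is still not told apart from that of compound 1. Nothing measured here accounts for the result or links it to any property of the methyl.

Still open is whether a different group at this position, such as an amine, a carboxylic acid or a longer chain like ethyl, would move the number beyond the scatter, since methyl is the only group shown here in place of hydrogen. Also open, on these data alone, is whether compound 1 and compound 3 would separate at lower concentrations, as a reading at one concentration cannot show this.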